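A few compounds are considered here, and "the series" means these few. Any claim that something is new, unique, unknown or untested is made for them only; others in the source may bear on it.

Going by the values given here, compound 1, `CC(C)Oc1cncc(C2=CC3CNCC(C2)C3)c1`, is the one compound in the set for which a number stands in an in vitro assay on SH-SY5Y cells for displacement of a labelled ligand from Neuronal acetylcholine receptor; alpha3/beta4 (Homo sapiens); a higher number here means a weaker inhibitor, a lower number a stronger inhibitor: compound 1 gives 4.8 nM. Compound 2, `COc1ccc(C2=CC3CC(C2)CN(C)C3)cn1`, is the other member, and in this assay compound 2 returns only a limit, > 10000 nM, with no number behind it. Among the compounds with values here, the two compounds differ in more than one place, so their two values show only that compound 1 has a number where compound 2 has a limit (the limit of > 10000 nM in this assay, at which 1 of the 2 values shown sits).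

Compound 3, `COc1cncc(C2=CC3CNCC(C2)C3)c1`, keeps the core of compound 1 and changes the alkoxy group on the aromatic ring. The difference is methyl in place of isopropyl on an oxygen on an aromatic ring, read one bond further out as isopropoxy to methoxy. No measured pair in the set isolates this change, so the size of the step cannot be read from what is shown.

For compound 3 a loss is expected in this assay, with the step from compound 1 to compound 3 estimated as a 6.3-fold higher number from compound 1 to compound 3 (0.80 log units; beyond the scatter), beyond the scatter but short of a limit. The expected value for compound 3 is 30 nM, within a range from 5 nM to 200 nM.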

Compound 3, inhibition constant: 14.3 nM
The estimate for compound 3 lay 2.1-fold (0.32 log units) above the measured number; the measured number falls inside the stated range.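

Going by these compounds alone, this is the first measured pair that isolates a single change, methyl in place of isopropyl on an oxygen on an aromatic ring, and in this assay that change gives a 3.0-fold higher number from compound 1 to compound 3 (0.47 log units; beyond the scatter) as a modest loss. The oxygen therefore carries either the isopropyl or the methyl group with a number on both sides of the step, and the smaller group leaves compound 3 at 14.3 nM in the same low range as the parent. Nothing measured on these compounds speaks to why the step has this size.

As far as these compounds go, whether an ethoxy group or a longer chain on the same oxygen would sit with compound 1, with compound 3 or elsewhere stays open, as does the outcome of replacing the whole alkoxy group with an amine or a hydroxyl group. Compound 2 differs from compound 3 in more than one place, so what separates its limit from the numbers of the other two compounds cannot be read from what is shown.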